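Replacing the amidine-like arm of compound 1 with an oxalate-type amide

A few compounds are considered here, and "the series" means these few. Any claim that something is new, unique, unknown or untested is made for them only; others in the source may bear on it.

Measured so far:
compound 1 `COc1ccc(N/C=N/C2=C(C#N)C3C(N4CCCC4)CCCCN3C(=O)N2c2ccccc2)cc1` — 50.2%
compound 2 `COc1ccc(/C=N/C2=C(C#N)C3C(N4CCCC4)CCCCN3C(=O)N2c2ccccc2)cc1` — 75.3%

Of the compounds shown here, two sharing one core have been measured in a functional assay on the whole organism (strain albino) for inhibition, with Rattus norvegicus as the target, read by paw edema, with stated times of 1 h and 3 h, at a dose of 20 mmol/kg by the intraperitoneal route; on this read-out higher numbers stand for a stronger effect at the one dose given and lower numbers for a weaker effect. Compound 1 gives 50.2%, the lower of the two numbers, and compound 2 gives 75.3%. Among the measured compounds shown here, the one step between them, a number 25.1 percentage points higher from compound 1 to compound 2 (beyond the scatter), shows that changing the group on the double-bonded ring carbon moves the read-out beyond the scatter.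

Compound 3 `COC(=O)C(=O)NC1=C(C#N)C2C(N3CCCC3)CCCCN2C(=O)N1c1ccccc1` is not yet measured. It differs from compound 1 by a group of 7 heavy atoms (3 carbon, 1 nitrogen, 3 oxygen; no ring) in place of a group of 11 heavy atoms (8 carbon, 2 nitrogen, 1 oxygen; one six-membered aromatic ring of carbon only), on a double-bonded ring carbon. This change sits at the same place that was altered between compound 1 and compound 2, so that step bears on it, but it does not tell the direction: the entering group shares nothing with the 4-methoxyphenyl that raised the number in compound 2. The account therefore expects a change of uncertain sign, most likely small, a number 4.8 percentage points higher from compound 1 to compound 3 (within the scatter). Compound 3 is estimated at 55%, with a range from 35% to 75%.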

Compound 3, a percentage reported as inhibition, in the whole organism at one dose (the size of the read-out at that dose, not a potency): 88.3%
Compound 3: the middle estimate sits 33.3 percentage points below what was measured, and the stated range ends below it.
By their numbers in this assay, from the lowest: compound 1; then compound 2; then compound 3.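

In this assay the ((methoxycarbonyl)carbonyl)amino group gives a number 38.1 percentage points higher from compound 1 to compound 3 (beyond the scatter) and also a number 13 percentage points higher from compound 2 to compound 3 (beyond the scatter), so compound 3 has the highest number of the three at the one dose given. Until now, both groups seen on this double-bonded ring carbon carried a six-membered aromatic ring of carbon only, and this result shows that the read-out at this position does not depend on such a ring: a smaller group with no ring gives a number beyond the scatter of both. The position therefore accepts groups of quite different make-up without loss of the read-out, yet nothing shown explains the size or direction of these steps.

The compounds shown leave open which part of the entering group carries the gain, since no compound here has a carboxylic acid in place of the methyl ester, or a simple acetyl group in place of the whole methoxycarbonyl-carbonyl unit. They also leave open whether the order of the three would hold at other doses, as each number is the size of the effect at a single dose and not a potency.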